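The source may hold more compounds than are shown below. What is called first, only, known or untested is meant among the compounds shown, and "the series" means these compounds.

In a functional assay on HeLa cells (Homo sapiens) for antiproliferative activity, read by sulforhodamine B assay, with a stated time of 72 h (on this read-out lower numbers stand for stronger inhibition and higher numbers for weaker inhibition), compound 1 `Cc1cccc(NC(=S)N/N=C/c2ccc3ccccc3n2)c1` returns only a limit, > 100000 nM, and so compound 1 stands at the limit of > 100000 nM in this assay, at which 1 of the 2 values shown sits, rather than at a measured number. In this assay compound 2 `NC(=S)N/N=C/c1nc2ccccc2s1` gives 5350 nM. Compound 3 `Fc1cccc(NC(=S)N/N=C/c2ccc3ccccc3n2)c1` differs from compound 1 in one place: fluoro in place of methyl on an aromatic carbon. Going by the values given here, no measured pair shows this change, so the step is expected to be a number no higher from compound 1 to compound 3 (the limit leaves the size open), which is none beyond the scatter, and the assay is expected to report only a limit again. Compound 3 is therefore estimated at 100000 nM, within a range from 20000 nM to 200000 nM.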

Compound 3, half-maximal inhibitory concentration: 70100 nM
Compound 3: the middle estimate sits 1.4-fold (0.15 log units) above what was measured; the range from low to high includes it.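

In this assay, the change from 3-methylphenyl to 3-fluorophenyl gives an at least 1.4-fold lower number from compound 1 to compound 3 (0.15 log units; that floor lies within the scatter). With fluoro on this aromatic carbon, the assay returns a measured number rather than a limit, so this position now has one firm reading. How large the step really is stays open, because one end of it is a limit: the limit of > 100000 nM in this assay, at which 1 of the 3 values shown sits.

The compounds shown leave open whether an amine, a hydroxyl or a chlorine at this same place would give a clearly lower number. They also leave open whether fluoro would behave alike on another carbon of that ring.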